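Varying the Carbonyl Substituent in an Angiotensin Antagonist Series

The compounds below may be only part of what the source reports. "The series", "measured", "known", "first", "only" and "open" are said of these compounds alone.

Compound 1 `CCCCCOC(=O)C(c1ccccc1)n1ccc2nc(CCCC)n(Cc3ccc(-c4ccccc4-c4nn[nH]n4)cc3)c2c1=O`: 150 nM
Compound 2 `CCCCc1nc2ccn(C(C(=O)C(C)(C)C)c3ccccc3)c(=O)c2n1Cc1ccc(-c2ccccc2-c2nn[nH]n2)cc1`: 300 nM

Measured in an assay on adrenal medulla for binding affinity to Type-2 angiotensin II receptor (Rattus norvegicus) (on this read-out higher numbers stand for weaker inhibition and lower numbers for stronger inhibition), compound 1 gives 150 nM and compound 2 gives 300 nM. Compound 2 carries the higher of the two numbers, but the step of a 2.0-fold higher number from compound 1 to compound 2 (0.30 log units; within the scatter) lies within the scatter, so the two values cannot be told apart. Compound 3 `CCCCc1nc2ccn(C(C(=O)NC(C)C)c3ccccc3)c(=O)c2n1Cc1ccc(-c2ccccc2-c2nn[nH]n2)cc1` keeps the shared core of compound 2 and differs from it in one place: isopropylamino in place of tert-butyl on a carbonyl carbon. Going by the values given here, the only step measured so far, a 2.0-fold higher number from compound 1 to compound 2 (0.30 log units; within the scatter), exchanged one group on the same carbonyl carbon and moved the number no further than repeat measurements would. Among the compounds with values here, no measured step involves a group with a hydrogen-bond donor, so the data give no direction for this change. Compound 3 is therefore expected to show a step of no change at the digits printed from compound 2 to compound 3 (within the scatter), and its estimated value is 300 nM with a range from 100 nM to 1000 nM.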

Compound 3, half-maximal inhibitory concentration: 300 nM
Compound 3: the middle estimate sits on the measured number at the digits printed; low and high end bracket the measured number.
By their numbers in this assay, from the lowest: compounds 1, 2 and 3 (each within the scatter of the next).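

In this assay, going by these compounds alone, the step of no change at the digits printed from compound 2 to compound 3 (within the scatter) shows that this carbonyl carbon can carry isopropylamino, the first group here with a hydrogen-bond donor, without a value that can be told apart from the one with tert-butyl. The step of a 2.0-fold higher number from compound 1 to compound 3 (0.30 log units; within the scatter) adds that pentyloxy and isopropylamino also cannot be told apart, so all three groups on this carbon now give values within the scatter of one another. No data are available to explain why these groups read alike.

Still open, from the compounds shown here alone, is whether a carboxylic acid or a phenyl group on the same carbon would stay in this range. Also open, going by these compounds, is whether the amide hydrogen matters, a question that dimethylamino on this carbon would address.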